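A few compounds are considered here, and "the series" means these few. Any claim that something is new, unique, unknown or untested is made for them only; others in the source may bear on it.

Working notes on the series. Among the compounds with values here, in a functional assay on NB-4 cells (Homo sapiens) for inhibition, read by XTT assay, with a stated time of 48 h (on this read-out lower numbers stand for stronger inhibition and higher numbers for weaker inhibition), compound 1 `COc1ccc(C(=O)/C(=C/C2CCCCC2)COC(C)=O)cc1` gives 23300 nM and compound 2 `COc1ccc(C(=O)/C(=C/C2CCCCC2)COC(=O)c2ccccc2)cc1` gives 10200 nM; on this assay compound 2 stands with the lowest of the two numbers, the only measured step being a 2.3-fold lower number from compound 1 to compound 2 (0.36 log units; beyond the scatter). Compound 3 `COc1ccc(C(=O)/C(=C/c2ccccc2Cl)COC(=O)c2ccccc2)cc1` is not yet measured. It differs from compound 2 by 2-chlorophenyl in place of cyclohexyl on a double-bonded chain carbon bound to a double-bonded chain carbon. Within the data shown here, the one measured step concerns a phenyl in place of methyl on a carbonyl carbon, a different position and a different pair of groups, so no measured step bears on the change from compound 2 to compound 3 and the direction is open. Compound 3 is therefore expected to give about 7000 nM, with a range from 2000 nM to 25000 nM. That estimate means an expected step of a 1.5-fold lower number from compound 2 to compound 3 (0.16 log units; within the scatter), small enough that either direction remains possible.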

Compound 3, half-maximal inhibitory concentration: 7000 nM
Compound 3: the middle estimate sits on the measured number at the digits printed; the measured number falls inside the stated range.
By their numbers in this assay, from the lowest: compounds 3 and 2 (each within the scatter of the next); then compound 1.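

In this assay, within the data shown here, the step of a 1.5-fold lower number from compound 2 to compound 3 (0.16 log units; within the scatter) is the first reading at this position, a double-bonded chain carbon bound to a double-bonded chain carbon. It shows that 2-chlorophenyl, an aromatic ring carrying chlorine, and cyclohexyl, a non-aromatic ring of carbon only, cannot be told apart here, so this change from one ring type to the other leaves the number within the scatter. Nothing measured here explains this result.

On these data alone, what an unsubstituted phenyl, a straight hexyl chain or an aminophenyl on this carbon would read remains open. Also open, as far as these compounds go, is whether the step on the carbonyl carbon, phenyl in place of methyl, would carry over with 2-chlorophenyl in place of cyclohexyl.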